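Amino for Ethoxy on a Carbonyl Carbon

The source may report more compounds than this note shows. Statements on the series, on what has been measured and on what is new or still open speak of the compounds shown alone.

In an ADME assay on a cell-free system (plasma, Homo sapiens) for metabolic stability, read by HPLC (a higher number here means that the compound lasts longer, a lower number that the compound disappears faster), compound 1 (`CCCC(CCC)C(=O)N(C)/N=N/c1ccc(C(=O)OCC)cc1`) gives > 40 h as its half-life, and that figure is a limit of the assay, not a number. Compound 2 (`CCCC(CCC)C(=O)N(C)/N=N/c1ccc(C(C)=O)cc1`), with methyl in place of ethoxy on a carbonyl carbon, gives > 40 h and this too is a limit. Going by the values given here, the one measured step that bears on the next change is a step that the two limits leave unreadable from compound 1 to compound 2 and it offers no size to build on. Taken together, the data show the limit of > 40 h in this assay, at which 2 of the 2 values shown sit, and nothing more.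

Compound 3 (`CCCC(CCC)C(=O)N(C)/N=N/c1ccc(C(N)=O)cc1`) differs from compound 1 at that same carbonyl carbon (amino in place of ethoxy on a carbonyl carbon) with amino in place of ethoxy. Compound 2 still reads > 40 h after its own change at this carbon, so no step beyond the usual scatter is expected for compound 3 in this assay and no direction can be named. The expected step is a step that the limit leaves unreadable from compound 1 to compound 3 and it rests on limits alone. For compound 3 the estimated half-life is 50 h with an expected range from 20 h to 120 h and the result may well come back as a limit again.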

Compound 3, half-life: > 40 h
Compound 3: a limit, no number; the forecaster's own chance of this, stated with the estimate: 75%; the middle value lies beyond the limit too.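

Going by these compounds alone, no step among compound 1, compound 2 and compound 3 can be read in this assay, since each result is a limit and not a number: the limit of > 40 h in this assay, at which 3 of the 3 values shown sit.

The compounds shown leave open how long each one actually lasts in this assay, and whether any change at this carbonyl carbon would shorten the half-life.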